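This account rests on a few compounds, and the source may have more. Where it says the series, first, only, none or still open, it means among the compounds named here.

Measured so far:
compound 1, `O=C(c1nccs1)c1nc(NCc2cccnc2)nc2ccsc12`: 176 nM
compound 2, `O=C(c1cncs1)c1nc(NCc2cccnc2)nc2ccsc12`: 148 nM

In a functional assay on CHO-K1 cells for antagonist activity at adenosine receptor A2b (Homo sapiens), read by FLIPR and calcium flux (on this read-out lower numbers stand for stronger inhibition and higher numbers for weaker inhibition), compound 2 gives 148 nM and compound 1 gives 176 nM; the two numbers lie within the scatter of each other, as the step of a 1.2-fold lower number from compound 1 to compound 2 (0.08 log units; within the scatter) shows. Compound 2 is thus one of a pair of near-identical numbers and has no separate standing on the data so far.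

Compound 3, `O=C(c1ccccc1)c1nc(NCc2cccnc2)nc2ccsc12`, differs from compound 2 by phenyl in place of 1,3-thiazol-5-yl on a carbonyl carbon. Within the data shown here, the only measured step, from one thiazolyl to another on that carbonyl carbon, was a 1.2-fold lower number from compound 1 to compound 2 (0.08 log units; within the scatter) and says little about the loss of both ring nitrogen and sulfur for a phenyl; no measured pair tests a carbon-only ring at this position. With that, no step beyond the scatter is expected in either direction, and the estimate is placed close to compound 2 with a wide range. The expected step is a 1.5-fold higher number from compound 2 to compound 3 (0.17 log units; within the scatter). Compound 3 is therefore expected to give about 220 nM, with a range from 80 nM to 650 nM.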

Compound 3, half-maximal inhibitory concentration: 511 nM
Estimate against measurement, compound 3: 2.3-fold (0.37 log units) below; the range from low to high includes it.
By their numbers in this assay, from the lowest: compounds 2 and 1 (each within the scatter of the next); then compound 3.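

In this assay, the ring on the carbonyl carbon now proves to matter: phenyl in place of 1,3-thiazol-5-yl gives a 3.5-fold higher number from compound 2 to compound 3 (0.54 log units; beyond the scatter), and phenyl in place of 1,3-thiazol-2-yl gives a 2.9-fold higher number from compound 1 to compound 3 (0.46 log units; beyond the scatter). The two thiazolyl rings remain within the scatter of each other, so at this position the separation so far lies between the five-membered rings with two hetero atoms and the six-membered ring of carbon only, although both steps are modest. No supporting data bear on the reason for this separation.

The change from thiazolyl to phenyl alters ring size and removes both ring hetero atoms at once, so the compounds shown leave open which of these differences goes with the higher numbers. A pyridinyl ring on the carbonyl carbon would keep the six-membered ring with a ring nitrogen, while a thienyl ring would keep the five-membered ring with sulfur as its only hetero atom, so each would separate these differences in a single step.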